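The source may report more compounds than this note shows. Statements on the series, on what has been measured and on what is new or still open speak of the compounds shown alone.

Compound 1, `O=C(O)c1ccc(C(=O)c2ccc(C(=O)c3ccc(C(=O)O)cc3)cc2)cc1`: 1000 nM
Compound 2, `O=C(O)c1ccc(C(=O)c2ccc(C(=O)c3ccccc3)cc2)cc1`: 40 nM
Compound 3, `O=C(O)c1ccc(C(=O)c2ccc(C(=O)c3ccc([N+](=O)[O-])cc3)cc2)cc1`: 100 nM

All three were measured in an assay on CHO cells for inhibition of 3-oxo-5-alpha-steroid 4-dehydrogenase 2 (Homo sapiens); on this read-out lower numbers stand for stronger inhibition and higher numbers for weaker inhibition. On those numbers compound 1 stands highest: the nearest is compound 3, and the furthest is compound 2. Both changes to the shared core of compound 1 lowered the number: a 25-fold lower number from compound 1 to compound 2 (1.40 log units; beyond the scatter), and a 10-fold lower number from compound 1 to compound 3 (1.00 log units; beyond the scatter). Between the two, a 2.5-fold higher number from compound 2 to compound 3 (0.40 log units; beyond the scatter).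

Compound 4, `O=C(O)c1ccc(C(=O)c2ccc(C(=O)c3ccc(Cl)c(Cl)c3)cc2)cc1`, has not yet been measured in this assay. It differs from compound 1 in one place: 3,4-dichlorophenyl in place of 4-carboxyphenyl on a carbonyl carbon. The two measured steps that bear on this both remove the carboxy from the same aromatic carbon, the first putting hydrogen there and the second nitro, and both lowered the number by a large or modest margin. Compound 4 also loses the carboxy, and the dichlorophenyl that enters carries no donor or acceptor, so a large step downward beyond the scatter is expected, a 33-fold lower number from compound 1 to compound 4 (1.52 log units; beyond the scatter). Compound 4 is therefore estimated at 30 nM, in the range 8 nM to 120 nM.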

Compound 4, inhibition constant: 35 nM
For compound 4 the middle estimate is 1.2-fold (0.07 log units) below the measured one; the range from low to high includes it.
By their numbers in this assay, from the lowest: compounds 4 and 2 (each within the scatter of the next); then compound 3; then compound 1.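

Replacing 4-carboxyphenyl with 3,4-dichlorophenyl on the carbonyl carbon also goes with a lower number in this assay (a 29-fold lower number from compound 1 to compound 4 (1.46 log units; beyond the scatter)), so the earlier drop now holds for a third group that has no carboxy. Compound 4 cannot be told apart from the unsubstituted phenyl of compound 2 (a 1.1-fold lower number from compound 2 to compound 4 (0.06 log units; within the scatter)), yet it does separate from the 4-nitrophenyl of compound 3 (a 2.9-fold lower number from compound 3 to compound 4 (0.46 log units; beyond the scatter)), which leaves compound 3 above the other two carboxy-free compounds. Nothing measured here accounts for these differences.

As far as these compounds go, it remains open whether a single chlorine would read like the pair, and whether an amine or a methoxy group on this phenyl would fall with compound 4 or with compound 3. From the compounds shown here alone, the part played by the carboxylic acid that all four compounds keep on the shared core is also open.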